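The source may hold more compounds than are shown below. What is called first, only, known or untested is meant among the compounds shown, and "the series" means these compounds.

Compound 1 `CN(Cc1ccccc1)/N=N/c1ccccc1` gives > 100000 nM in an ADME assay on BHK-21 cells (Mesocricetus auratus) for cytotoxicity, read by MTT assay, with a stated time of 96 h (on this read-out lower numbers stand for higher toxicity in this test and higher numbers for lower toxicity in this test), and this figure is a limit of the test, not a number. Compound 3 `CN(/N=N/c1cccc([N+](=O)[O-])c1)c1ccccc1` gives > 100000 nM, which is likewise a limit. Within the data shown here, compound 2 `CN(C)CCCNc1ccc(/N=N/c2c(F)cccc2F)cc1` gives 43000 nM, the only true number so far. Compound 1 therefore stands at the limit of > 100000 nM in this assay, at which 2 of the 3 values shown sit.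

The next compound to be tested, compound 4 `c1ccc(CN/N=N/c2ccccc2)cc1`, is a close relative of compound 1. The structural change is hydrogen in place of methyl on an amine nitrogen, in words hydrogen in place of methyl on an amine nitrogen. The rest of the core of compound 1 stays as it is.

Among the measured compounds shown here, no measured pair here differs in one place only, so no earlier step can serve as a guide to the size of this one. The expectation rests mainly on compound 1, whose > 100000 nM is a limit. The expected step, an at least 1.2-fold lower number from compound 1 to compound 4 (0.09 log units; that floor lies within the scatter), is none beyond the usual scatter of this assay, and any drift would be toward lower numbers. The test may well report only a limit again. For compound 4, the estimated half-maximal cytotoxic concentration is 80000 nM, with an expected range from 30000 nM to 200000 nM.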

Compound 4, half-maximal cytotoxic concentration: > 100000 nM
Compound 4 gave a limit, no number (the forecaster's own chance of this, stated with the estimate: 55%); middle value at least 1.2-fold (0.09 log units) from the limit.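

In this assay compound 4 gives > 100000 nM as a limit and not a number. Compound 1 gives > 100000 nM as a limit too, so no step can be read between compound 1 and compound 4. The compounds shown leave open how far, if at all, hydrogen in place of methyl on an amine nitrogen moves this read-out, as most values share one limit: the limit of > 100000 nM in this assay, at which 3 of the 4 values shown sit.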